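The source may report more compounds than this note shows. Statements on the series, on what has been measured and on what is new or still open speak of the compounds shown alone.

Series notes, a functional assay on MCF7 cells (Homo sapiens) for antiproliferative activity, read by MTT assay, with a stated time of 24 h; on this read-out lower numbers stand for stronger inhibition and higher numbers for weaker inhibition. Compound 1 `c1ccc(-c2noc(-c3ccncc3)n2)cc1` gives > 1000000 nM, which is a limit and not a number. Compound 2 `COc1ccc(-c2noc(-c3ccccc3)n2)cc1OC1CCCC1` gives > 1000000 nM, again a limit. Compound 3 `COc1ccc(-c2noc(-c3ccncc3)n2)cc1OC1CCCC1` gives > 1000000 nM, also only a limit. Compound 3 therefore has no readable position in the series, and (the limit of > 1000000 nM in this assay, at which 3 of the 3 values shown sit).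

Compound 4 `COc1ccc(-c2noc(C3CCCN3)n2)cc1OC1CCCC1` carries pyrrolidin-2-yl in place of the pyridin-4-yl of compound 3, on an aromatic carbon of the five-membered aromatic ring: pyrrolidin-2-yl in place of pyridin-4-yl on an aromatic carbon. Among the compounds with values here, the change brings in a non-aromatic ring and a hydrogen-bond donor, which no measured compound shows at this place.

Within the data shown here, the one measured step that bears on it is a step that the two limits leave unreadable from compound 2 to compound 3, so it offers no size to carry over. The expectation is therefore that compound 4 stays close to the same limit, with any shift towards stronger inhibition. The expected step is an at least 1.4-fold lower number from compound 3 to compound 4 (0.15 log units; that floor lies within the scatter). Compound 4 is estimated at 700000 nM, with an expected range of 80000 nM to 1500000 nM.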

Compound 4, half-maximal inhibitory concentration: > 1000000 nM
Compound 4 ended at the assay's limit; the forecaster's own chance of this, stated with the estimate: 60%; middle value at least 1.4-fold (0.15 log units) from the limit.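

Within the data shown here, compound 4 also reads as a limit and not a number, so no step from compound 2 or compound 3 to compound 4 can be read, and the series stays at: the limit of > 1000000 nM in this assay, at which 4 of the 4 values shown sit. The compounds shown leave open whether any group at this place changes the antiproliferative read-out.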